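The source may hold more compounds than are shown below. What is called first, only, known or untested is meant among the compounds shown, and "the series" means these compounds.

Measured so far in a physicochemical assay for solubility, read by HPLC, using the shake flask method, in phosphate buffer, measured as kinetic solubility, with a stated time of 20 h, at pH 6.5; on this read-out higher numbers stand for higher solubility and lower numbers for lower solubility:
- compound 1 `C[C@@H]1CN(C(=O)c2ccnc(Nc3nc4cnc(Nc5cccc(C(F)(F)F)c5)cc4[nH]3)c2)C[C@H](C)N1`: 200000 nM
- compound 2 `C[C@@H]1CN(C(=O)c2ccnc(Nc3nc4cnc(-c5ccc(F)c(C(F)(F)F)c5)cc4[nH]3)c2)C[C@H](C)N1C`: 180000 nM

Only these two compounds have been measured in this assay, and their numbers lie within the scatter of each other. Compound 2, at 180000 nM, therefore stands level with compound 1 at 200000 nM, and the pair cannot be ranked.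

The next compound, compound 3 `CC(C)N1CC2CC1CN2C(=O)c1ccnc(Nc2nc3cnc(-c4ccc(F)c(C(F)(F)F)c4)cc3[nH]2)c1`, keeps everything in compound 2 except the amine part of the amide. The 3,4,5-trimethylpiperazin-1-yl group on the carbonyl carbon gives way to a group with no common name, containing two five-membered non-aromatic rings: a group of 10 heavy atoms (8 carbon, 2 nitrogen; 2 five-membered non-aromatic rings with 1 hetero atom each) in place of a group of 9 heavy atoms (7 carbon, 2 nitrogen; one six-membered non-aromatic ring with 2 hetero atoms), on a carbonyl carbon.

Within the data shown here, no measured step between closely matched compounds bears on this change, so the expectation rests only on the two numbers so far, which sit close together. In this assay the expected result is a 1.1-fold lower number from compound 2 to compound 3 (0.05 log units; within the scatter), which would be no change beyond the scatter, though the uncertainty is wider on the low side.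

For compound 3 the estimated value is 160000 nM, with an expected range from 70000 nM to 220000 nM.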

Compound 3, solubility: 155000 nM
Compound 3: middle estimate off by 1.0-fold (0.01 log units), on the high side; the measured number falls inside the stated range.
By their numbers in this assay, from the lowest: compounds 3, 2 and 1 (each within the scatter of the next).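

In this assay, among these compounds, the replacement of 3,4,5-trimethylpiperazin-1-yl on the carbonyl carbon gives a 1.2-fold lower number from compound 2 to compound 3 (0.06 log units; within the scatter) and so supplies the first step in which only this amine part of the amide differs. Compounds 1 and 2 differ in more than one place and could not isolate this position, whereas this single step shows that a group with two five-membered non-aromatic rings and no defined stereocentres can take the place of a six-membered non-aromatic ring with two defined stereocentres without a difference beyond the scatter on this read-out. No measurement shown offers an account of this result.

On these data alone, whether the same holds for a smaller amine such as azetidin-1-yl, or for a piperazin-1-yl group carrying a carboxylic acid on a longer chain, remains open, since this single step covers only the two groups compared. As far as these compounds go, it is also open whether the same replacement would read alike on the core of compound 1, and how either group would behave in any other assay.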